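A Bromoethyl Chain in Place of a Carboxyethenyl Chain

The compounds below may be only part of what the source reports. "The series", "measured", "known", "first", "only" and "open" are said of these compounds alone.

Three compounds sharing the core of compound 2 `CCCCCCc1ccc(C(=O)/C=C\C(=O)O)cc1` have been measured in an in vitro assay on BL21-DE3 cells for displacement of a labelled ligand from thyroid hormone receptor beta (Homo sapiens), read by fluorescence polarization; a higher number here means a weaker inhibitor, a lower number a stronger inhibitor. Compound 2 gives 17700 nM, the second highest of the three numbers. Compound 3 `C=C(C)C(=O)c1ccc(CCCCCCC)cc1` gives 23200 nM, which lies within the usual scatter of the value of compound 2, so no order between the two can be claimed. Compound 1 `CCCCCCc1ccc(C(=O)CCN(CCCC)CCCC)cc1` gives 4200 nM, a lower number than compound 2 by more than the scatter. Compound 4 `CCCCCCc1ccc(C(=O)CCBr)cc1` is not yet measured; it differs from compound 2 by 2-bromoethyl in place of 2-carboxyethenyl on a carbonyl carbon. Among the measured compounds shown here, no measured pair shows this change, so only a rough expectation is possible. The estimate for compound 4 in this assay is 10000 nM, with a range from 3000 nM to 40000 nM. The expected step of a 1.8-fold lower number from compound 2 to compound 4 (0.25 log units; within the scatter) is a modest move toward a lower number, near the edge of the scatter.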

Compound 4, half-maximal inhibitory concentration: 3000 nM
For compound 4 the middle estimate is 3.3-fold (0.52 log units) above the measured one, and the stated range covers the measured number.
By their numbers in this assay, from the lowest: compounds 4 and 1 (each within the scatter of the next); then compounds 2 and 3 (each within the scatter of the next).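

In this assay, the change gives a 5.9-fold lower number from compound 2 to compound 4 (0.77 log units; beyond the scatter), the first step read at this position on a carbonyl carbon, and it lies beyond the scatter. The carboxylic acid of the 2-carboxyethenyl chain is therefore not needed for binding at this level, and a chain with no hydrogen-bond donor or acceptor serves here. Nothing measured explains the step.

The change swaps the acid, both double bonds and the bromine at once, so their shares remain unseparated. A saturated 2-carboxyethyl chain or a 2-chloroethyl chain would begin to divide them.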